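Diethylamino for Dimethylamino: Expecting Compound 4

This account rests on a few compounds, and the source may have more. Where it says the series, first, only, none or still open, it means among the compounds named here.

All numbers here come from a functional assay on Caco-2 cells (Homo sapiens), read by MTT assay, with a stated time of 48 h; a higher number here means a weaker inhibitor, a lower number a stronger inhibitor.

Compound 1, `CCn1c(C(=O)NCCCN(C)C)ccc1C(CC)(CC)c1ccc(OCC(=O)C(C)(C)C)c(C)c1`: compound 1 gives 1400 nM.
Compound 2, `CCN(CC)CCCNC(=O)c1ccc(C(CC)(CC)c2ccc(OCC(=O)C(C)(C)C)c(C)c2)n1CC`: compound 2 gives 1000 nM.
Compound 3, `CCn1c(C(=O)NCCCN(C)C)ccc1C(CC)(CC)c1ccc(OCC(O)C(C)(C)C)c(C)c1`: compound 3 gives 1900 nM.

The three measured compounds sit close together. Compound 1 and compound 2 differ by diethylamino in place of dimethylamino on a saturated chain carbon, three bonds along the chain from an amide-type nitrogen, and the step that goes with it is a 1.4-fold lower number from compound 1 to compound 2 (0.15 log units; within the scatter). Compound 1 and compound 3 differ in their cores by 1-hydroxy-2,2-dimethylpropyl in place of (tert-butyl)carbonyl on a saturated chain carbon bound to an oxygen on an aromatic ring, with a step of a 1.4-fold higher number from compound 1 to compound 3 (0.13 log units; within the scatter). Neither move leaves the usual scatter, so these three compounds are best read as one group rather than as a ranked series.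

Compound 4, `CCN(CC)CCCNC(=O)c1ccc(C(CC)(CC)c2ccc(OCC(O)C(C)(C)C)c(C)c2)n1CC`, has not been measured in this assay. It stands to compound 3 as compound 2 stands to compound 1: the change is diethylamino in place of dimethylamino on a saturated chain carbon, three bonds along the chain from an amide-type nitrogen, and since the place of the change is described in the same words for both pairs, it is the same change made on the core of compound 3 rather than on the core of compound 1.

Among the measured compounds shown here, the one earlier instance of this change, a 1.4-fold lower number from compound 1 to compound 2 (0.15 log units; within the scatter), was small. The expected step from compound 3 to compound 4 is therefore also small, a 1.4-fold lower number from compound 3 to compound 4 (0.13 log units; within the scatter), resting only on that single prior step and on the near-equality of the two cores seen in a 1.4-fold higher number from compound 1 to compound 3 (0.13 log units; within the scatter). With that, compound 4 is estimated at 1400 nM in this assay, and the range 700 nM to 2800 nM is expected to cover it.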

Compound 4, half-maximal inhibitory concentration: 1800 nM
The estimate for compound 4 lay 1.3-fold (0.11 log units) below the measured number; low and high end bracket the measured number.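

In this assay, diethylamino in place of dimethylamino, carried to the core that bears 1-hydroxy-2,2-dimethylpropyl, gave a 1.1-fold lower number from compound 3 to compound 4 (0.02 log units; within the scatter), and its two instances agree: the same change on two cores in this assay, a 1.4-fold lower number (0.15 log units; within the scatter) from compound 1 to compound 2 and a 1.1-fold lower number (0.02 log units; within the scatter) from compound 3 to compound 4, 1.3-fold (0.12 log units) apart, within the scatter of two such steps Read the other way, 1-hydroxy-2,2-dimethylpropyl in place of (tert-butyl)carbonyl gave a 1.8-fold higher number from compound 2 to compound 4 (0.26 log units; within the scatter), and this change also agrees across its two instances: the same change on two cores in this assay, a 1.4-fold higher number (0.13 log units; within the scatter) from compound 1 to compound 3 and a 1.8-fold higher number (0.26 log units; within the scatter) from compound 2 to compound 4, 1.3-fold (0.12 log units) apart, within the scatter of two such steps The two changes therefore carried from one core to the other without a visible difference, but every step lies within the scatter, and a comparison of two small steps on two cores shows neither that either change has a real effect on the number nor that the agreement would hold on any other core in the series.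

The four compounds hold only dimethylamino or diethylamino at the end of the chain, which leaves open how a piperidine, a morpholine or a primary amine in that place, or a longer chain leading to the amine, would read in this assay. Also open, on these data alone, is whether a methyl ether or a primary amine in place of the hydroxyl of the 1-hydroxy-2,2-dimethylpropyl group would give a step that leaves the scatter.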